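This account rests on a few compounds, and the source may have more. Where it says the series, first, only, none or still open, it means among the compounds named here.

Measured so far:
compound 1, `Nc1cc(N)c2nc(-c3ccccc3)c(NCc3ccc(Cl)c(Cl)c3)nc2c1`, in a functional assay on OVCAR-4 cells (Homo sapiens) for inhibition, read by sulforhodamine B assay, with a stated time of 48 h (on this read-out lower numbers stand for stronger inhibition of growth and higher numbers for weaker inhibition of growth), gives < 100000 nM, a limit of the assay and not a number;
compound 2, `Nc1cc(N)c2nc(-c3ccccc3)c(NCc3ccc(F)cc3)nc2c1`, in this assay gives 8130 nM.

The reading for compound 1 is only a limit (the limit of < 100000 nM in this assay, at which 1 of the 2 values shown sits). Within the data shown here, compound 2 therefore stands as the single number in this assay, with the limit for compound 1 beside it. Among the measured compounds shown here, the one step between measured compounds, a step that the limit leaves unreadable from compound 1 to compound 2, cannot be sized.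

Compound 3, `COc1ccc(CNc2nc3cc(N)cc(N)c3nc2-c2ccccc2)cc1`, is yet to be measured in this assay. It differs from compound 2 by methoxy in place of fluoro on an aromatic carbon. No readable step bears on this change: the step from compound 1 to compound 2 alters substituents on the same ring but is unreadable. Nothing in hand supports expecting a step beyond the scatter in either direction. The estimate for compound 3 is 8000 nM, range 2500 nM to 25000 nM. This expected value implies a step of a 1.0-fold lower number from compound 2 to compound 3 (0.01 log units; within the scatter).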

Compound 3, concentration for total growth inhibition: 21400 nM
Compound 3: middle estimate off by 2.7-fold (0.43 log units), on the low side; low and high end bracket the measured number.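

In this assay, among these compounds, methoxy in place of fluoro gives the first readable step: a 2.6-fold higher number from compound 2 to compound 3 (0.42 log units; beyond the scatter). The place para to a large group is therefore not indifferent to what it carries, and of this pair the 4-fluorobenzyl compound has the lower number, which stands for stronger inhibition of growth. The steps from compound 1 cannot be read, and its reading remains a limit of the assay and not a number: the limit of < 100000 nM in this assay, at which 1 of the 3 values shown sits.

A single readable pair at this place gives no trend across substituents, and it does not tell which part of the change from fluoro to methoxy carries the step. As far as these compounds go, whether a hydroxyl, a dimethylamino group or a nitrile at the same place would track with fluoro, with methoxy or with neither remains open.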